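A few compounds are considered here, and "the series" means these few. Any claim that something is new, unique, unknown or untested is made for them only; others in the source may bear on it.

Measured so far in a functional assay on brain for inhibition of Norepinephrine transporter (Rattus norvegicus); on this read-out lower numbers stand for stronger inhibition and higher numbers for weaker inhibition:
Compound 2, `CN(C)C/C=C(/c1ccc(Cl)cc1)c1cccnc1`, gives 10000 nM.
Compound 1, `CN(C)C/C=C(/c1ccccc1)c1cccnc1`, gives 27000 nM.

Compound 2 stands at the lowest of the two numbers in this assay; its nearest neighbour is compound 1, and the step of a 2.7-fold lower number from compound 1 to compound 2 (0.43 log units; beyond the scatter) came from a chloro in place of hydrogen on an aromatic carbon. Among the compounds with values here, that is the only step measured here, and it is modest.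

Compound 3, `CN(C)C/C=C(/c1ccc(I)cc1)c1cccnc1`, has not yet been measured. It differs from compound 2 by iodo in place of chloro on an aromatic carbon. Within the data shown here, no measured step involves an iodo group, so the one step that bears on this change only indirectly is the one from compound 1 to compound 2, which shows that a halogen at this place is tolerated and helped somewhat. Exchanging one halogen for another at the same place is expected to give a smaller step than that, in this assay most likely no change beyond the scatter, with a slight lean towards a lower number. Compound 3 is therefore estimated at 7000 nM, between 2500 nM and 20000 nM, corresponding to an expected step of a 1.4-fold lower number from compound 2 to compound 3 (0.15 log units; within the scatter).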

Compound 3, half-maximal inhibitory concentration: > 22000 nM
Compound 3 ended at the assay's limit; the forecaster's own chance of this, stated with the estimate: 5%; at least 3.1-fold (0.49 log units) between middle value and limit.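

In this assay compound 3 gives > 22000 nM, and this is a limit of the assay, not a number: the limit of > 22000 nM in this assay, at which 1 of the 3 values shown sits.

Even so, the comparison with the chloro compound can be read in one direction: iodo in place of chloro gives an at least 2.2-fold higher number from compound 2 to compound 3 (0.34 log units; beyond the scatter) and so shows that this position, para to a large group, does not treat the two halogens alike. As far as these compounds go, the modest gain seen with chloro therefore does not extend to iodo, and a halogen at this place cannot be assumed to help; the step from hydrogen to iodo, however, cannot be read, so it remains unknown how the iodo compound compares with the unsubstituted one.

From the compounds shown here alone, how far the true value of compound 3 lies past the limit also remains open, and so does the size of the real loss on going from chloro to iodo. A fluoro or bromo group at the same aromatic carbon, or a methyl or methoxy group there, would show whether chloro is a special case or part of a wider trend.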